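The source may report more compounds than this note shows. Statements on the series, on what has been measured and on what is new or still open speak of the compounds shown alone.

In a functional assay on a cell-free system (Platelet, plasma, Homo sapiens) for inhibition (on this read-out higher numbers stand for weaker inhibition and lower numbers for stronger inhibition), compound 1 `O=C(Nc1cccc(OCc2ccccc2)c1)C1CCNCC1` gives 229000 nM and compound 2 `O=C(Nc1cccc(OCc2ccc(-c3ccccc3F)cc2)c1)C1CCNCC1` gives 62700 nM, the lower of the two numbers. Compound 3 `O=C(Nc1cccc(OCc2ccc(-c3cc(F)cc(F)c3)cc2)c1)C1CCNCC1` carries 3,5-difluorophenyl in place of 2-fluorophenyl on an aromatic carbon. For the measured compounds named here, the only measured step that bears on this is a 3.7-fold lower number from compound 1 to compound 2 (0.56 log units; beyond the scatter), a modest one. It introduced the 2-fluorophenyl but shows nothing about exchanging it for 3,5-difluorophenyl, so no change beyond the scatter is expected in this assay. The expected step is a 1.1-fold lower number from compound 2 to compound 3 (0.05 log units; within the scatter). For compound 3 the estimated value is 56000 nM, with an expected range of 22000 nM to 130000 nM.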

Compound 3, half-maximal inhibitory concentration: 27800 nM
For compound 3 the middle estimate is 2.0-fold (0.30 log units) above the measured one; measured number inside the range.
By their numbers in this assay, from the lowest: compound 3; then compound 2; then compound 1.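

In this assay, the change from 2-fluorophenyl to 3,5-difluorophenyl is a 2.3-fold lower number from compound 2 to compound 3 (0.35 log units; beyond the scatter), so the group at this place matters beyond merely being a fluorinated phenyl ring. Set against hydrogen at the same aromatic carbon, 3,5-difluorophenyl gives an 8.2-fold lower number from compound 1 to compound 3 (0.92 log units; beyond the scatter). Nothing available here explains the difference between the two groups.

Open, going by these compounds, is whether the step follows the number of fluorine atoms or where they sit on the ring. Also open, on these data alone, is how a plain phenyl, or a phenyl carrying an amine or a carboxylic acid, would compare at this place.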